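A few compounds are considered here, and "the series" means these few. Any claim that something is new, unique, unknown or untested is made for them only; others in the source may bear on it.

Measured in a functional assay on the whole organism for inhibition, with Mus musculus as the target; a higher number here means that more compound is needed for the effect, a lower number that less compound is needed:

- Compound 1 `CC(C)c1ccc(C2CN(C)Cc3c(N)cccc32)cc1`: > 80 mg/kg
- Compound 2 `CCOC(=O)Nc1cccc2c1CN(C)CC2c1ccc(Cl)cc1`: 4.8 mg/kg
- Compound 3 `CN1Cc2c(NC(=O)OCc3ccccc3)cccc2C(c2ccccc2)C1`: about 15 mg/kg

The entry for compound 1, > 80 mg/kg, is a limit of the assay and not a number. Among the compounds with values here, only two true numbers can therefore be compared. Compound 3, at about 15 mg/kg, has the higher number, so more of it is needed for the effect. Compound 2, at 4.8 mg/kg, lies lower, and this gap is beyond the usual scatter.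

Compound 4 `CCCCNCCC(=O)Nc1cccc2c1CN(C)CC2c1ccccc1` has 2-(butylamino)ethyl in place of benzyloxy on a carbonyl carbon. Within the data shown here, no measured pair differs in just one place, so no earlier step shows what such a swap does in this assay. Compound 4 keeps the carbonyl of compound 3 at about 15 mg/kg, so a number of similar size is expected. A small rise, within the scatter, is expected: a 1.3-fold higher number from compound 3 to compound 4 (0.12 log units; within the scatter). The estimate for compound 4 is 20 mg/kg, with an expected range from 5 mg/kg to 70 mg/kg.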

Compound 4, dose for half-maximal effect: about 46 mg/kg
Compound 4: the middle estimate sits 2.3-fold (0.36 log units) below what was measured; the range from low to high includes it.
By their numbers in this assay, from the lowest: compound 2; then compound 3; then compound 4. At a limit, above all of these: compound 1.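

The carbonyl on the amide-type nitrogen tolerates a large change: with 2-(butylamino)ethyl in place of benzyloxy, the compound still acts in this assay, though more of it is needed, a 3.1-fold higher number from compound 3 to compound 4 (0.49 log units; beyond the scatter). Within the data shown here, this is the first single-place step, and it puts a size on this swap, which the earlier compounds could not do. Compound 1 alone sits at a limit of the assay and not a number, and compound 4 does not reach it: the limit of > 80 mg/kg in this assay, at which 1 of the 4 values shown sits.

This one swap removes the aromatic ring and brings in the nitrogen together, so the data cannot say which of the two goes with the higher number. A plain hexyl chain, which has no nitrogen, or a benzylamino group, which keeps a ring and has a nitrogen, on the same carbonyl would pull the two apart.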